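This account rests on a few compounds, and the source may have more. Where it says the series, first, only, none or still open, it means among the compounds named here.

Measured so far in a functional assay on SK-BR-3 cells (Homo sapiens) for cytotoxicity, read by MTT assay, with a stated time of 72 h; a higher number here means that more compound is needed for the effect, a lower number that less compound is needed:
compound 1, `CCc1cccc2c(OC)c(-c3occ(C)c3C(=O)OC)ccc12`: 1.2 ug/mL
compound 2, `CCc1cccc2c(OC)c(-c3occ(C)c3COC)ccc12`: a limit of this assay, > 10 ug/mL
compound 3, `CCc1cccc2c(OC)c(-c3occ(C)c3CBr)ccc12`: a limit of this assay, > 10 ug/mL

Within the data shown here, compound 3 stands at the upper limit of this assay, with no number behind it; compound 1 is the only member of the series with a measured number, and the limit of > 10 ug/mL in this assay, at which 2 of the 3 values shown sit, marks where the other two sit. Compound 4, `CCc1cccc2c(OC)c(-c3occ(C)c3COCC(F)(F)F)ccc12`, is the next member. It differs from compound 3 in one place: 2,2,2-trifluoroethoxy in place of bromo on a saturated chain carbon bound to an aromatic carbon.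

Of the measured steps, the one at the same place is a step that the two limits leave unreadable from compound 2 to compound 3, which two limits leave without a readable size. The two readable steps both start from compound 1: an at least 8.3-fold higher number from compound 1 to compound 2 (0.92 log units; beyond the scatter) and an at least 8.3-fold higher number from compound 1 to compound 3 (0.92 log units; beyond the scatter), each an at least modest rise to the limit once methoxycarbonyl is replaced on that aromatic carbon. Compound 4 keeps a methylene carrying an ether oxygen at that position, as compound 2 does, so no return toward the number of compound 1 is expected, and the step that the limit leaves unreadable from compound 3 to compound 4 is expected to remain unreadable in this assay. Compound 4 is therefore estimated at 20 ug/mL, most likely reported only as a limit, within a range of 8 ug/mL to 60 ug/mL.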

Compound 4, concentration for half-maximal effect: 5.3 ug/mL
Estimate against measurement, compound 4: 3.8-fold (0.58 log units) above, outside the stated range (below it).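

In this assay, compound 4 is the only compound shown without methoxycarbonyl on that aromatic carbon to give a number rather than a limit, so losing that group does not by itself take the series to the limit. Methoxycarbonyl still gives the lower number of this pair, with a 4.4-fold higher number from compound 1 to compound 4 (0.65 log units; beyond the scatter). The ether oxygen alone does not decide the outcome, since compound 2 also has a methylene carrying an ether oxygen and differs from compound 4 by trifluoromethyl in place of hydrogen; the two steps into compound 4 are an at least 1.8-fold lower number from compound 3 to compound 4 (0.27 log units; that floor lies within the scatter) and an at least 1.8-fold lower number from compound 2 to compound 4 (0.27 log units; that floor lies within the scatter), so each gives only a floor, and neither floor lies beyond the scatter.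

Compound 2 and compound 3 remain limits, so the true size of those steps and the step between these two compounds cannot be read: the limit of > 10 ug/mL in this assay, at which 2 of the 4 values shown sit. On these data alone, whether an amine, a carboxylic acid or a longer chain on that saturated chain carbon would bring the number closer to that of compound 1 remains open.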